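The source may hold more compounds than are shown below. What is called first, only, known or untested is meant among the compounds shown, and "the series" means these compounds.

Measured so far:
- compound 1, `O=c1nc2oc(CCCCl)cc2cn1Cc1cn(-c2ccc(Cl)cc2)nn1`: > 100000 nM
- compound 2, `O=c1nc2oc(C3CC3)c(C#CC3CC3)c2cn1Cc1cn(-c2ccc(Cl)cc2)nn1`: 36900 nM

Both compounds were tested in a functional assay on SW-620 cells (Homo sapiens) for antiproliferative activity, read by MTT assay, with a stated time of 72 h; on this read-out lower numbers stand for stronger inhibition and higher numbers for weaker inhibition. For compound 1 the result of > 100000 nM is a limit of the assay rather than a number. Within the data shown here, compound 2 gives 36900 nM, the only number among the two values shown. The other value, that of compound 1, is a limit (the limit of > 100000 nM in this assay, at which 1 of the 2 values shown sits). Compound 3, `O=c1nc2oc(C3CC3)cc2cn1Cc1cn(-c2ccc(Cl)cc2)nn1`, has not yet been measured. It differs from compound 2 in one place: hydrogen in place of 2-cyclopropylethynyl on an aromatic carbon, so the shared core keeps only the cyclopropyl group on the five-membered ring. Among the measured compounds shown here, no measured pair shows what this change does on its own. Since compound 2 gives 36900 nM, which is already weak, the removal of a group is expected to weaken activity further. The expected step is a 2.4-fold higher number from compound 2 to compound 3 (0.39 log units; beyond the scatter). For compound 3 there is a real chance that only a limit is reported. Compound 3 is thus estimated at 90000 nM, within a range from 35000 nM to 250000 nM.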

Compound 3, half-maximal inhibitory concentration: > 100000 nM
Compound 3: only a limit was reported; the forecaster's own chance of this, stated with the estimate: 45%; middle value at least 1.1-fold (0.04 log units) away from the limit.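

In this assay, putting hydrogen in place of 2-cyclopropylethynyl on this aromatic carbon gives an at least 2.7-fold higher number from compound 2 to compound 3 (0.43 log units; beyond the scatter), the first single-change view of this position. The result for compound 3 is a limit of the assay, not a number, so the real size of the step may be larger than what is printed. In this pair, then, the measurable if weak activity of compound 2 depends on the 2-cyclopropylethynyl group, while the step between compound 1 and compound 3 cannot be read, since both results are limits: the limit of > 100000 nM in this assay, at which 2 of the 3 values shown sit.

The compounds shown leave open whether the triple bond, the cyclopropyl ring at its end or simply any carbon group at this position matters. A plain ethyl chain, a phenyl ring or an amine on the same carbon would help separate these possibilities.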